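Chain variants on the shared core: allyl to 2-hydroxyethyl

The source may hold more compounds than are shown below. What is called first, only, known or untested is meant among the compounds shown, and "the series" means these compounds.

Values in a functional assay on OVCAR-8 cells (Homo sapiens) for antiproliferative activity (on this read-out lower numbers stand for stronger inhibition and higher numbers for weaker inhibition), so far:
- compound 1 `Cn1ncc(Cl)c1-c1cc(C(=O)N[C@@H]2CN[C@H](CCCO)C[C@H]2c2ccc(Cl)c(Cl)c2)oc1Cl` gives 600 nM
- compound 2 `Cn1ncc(Cl)c1-c1cc(C(=O)N[C@@H]2CN[C@H](CCN3CCCCC3)C[C@H]2c2ccc(Cl)c(Cl)c2)oc1Cl` gives 1660 nM
- compound 3 `C=CC[C@@H]1C[C@@H](c2ccc(Cl)c(Cl)c2)[C@H](NC(=O)c2cc(-c3c(Cl)cnn3C)c(Cl)o2)CN1` gives 990 nM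

Compound 3 at 990 nM lies within the scatter of both compound 1 and compound 2. For the measured compounds named here, those two are apart, and the one step beyond the scatter is a 2.8-fold higher number from compound 1 to compound 2 (0.44 log units; beyond the scatter) and it is modest.

The next change leads to compound 4 `Cn1ncc(Cl)c1-c1cc(C(=O)N[C@@H]2CN[C@H](CCO)C[C@H]2c2ccc(Cl)c(Cl)c2)oc1Cl` and is counted as hydroxymethyl in place of vinyl on a saturated chain carbon bound to a saturated ring carbon in words hydroxymethyl in place of vinyl on a saturated chain carbon bound to a saturated ring carbon. Cut one bond further out, it reads allyl to 2-hydroxyethyl.

Going by the values given here, two measured steps bear on it. The closer is a 1.7-fold higher number from compound 1 to compound 3 (0.22 log units; within the scatter) with vinyl in place of 2-hydroxyethyl at that place. The other is a 1.7-fold lower number from compound 2 to compound 3 (0.22 log units; within the scatter) with vinyl in place of (piperidin-1-yl)methyl there. Neither leaves the scatter. Among the compounds with values here, compound 4 has hydroxymethyl where compound 1 has 2-hydroxyethyl, so compound 1 at 600 nM is the nearest guide, though no compound with hydroxymethyl there has been measured.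

No step beyond the scatter is therefore expected in this assay with a slight lean towards a lower number. The expected step is a 1.3-fold lower number from compound 3 to compound 4 (0.12 log units; within the scatter). The estimate for compound 4 is 750 nM with an expected range from 350 nM to 1600 nM.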

Compound 4, half-maximal inhibitory concentration: 610 nM
Compound 4: the middle estimate sits 1.2-fold (0.09 log units) above what was measured; measured number inside the range.
By their numbers in this assay, from the lowest: compounds 1, 4, 3 and 2 (each within the scatter of the next, the first and the last beyond it).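

In this assay, the step to the 2-hydroxyethyl chain is a 1.6-fold lower number from compound 3 to compound 4 (0.21 log units; within the scatter) and so gives no separation from the allyl chain, while the chain ends in hydroxy in both members of the pair a 1.0-fold higher number from compound 1 to compound 4 (0.01 log units; within the scatter) and shortening that chain by one carbon leaves the two numbers indistinguishable. The piperidin-1-yl chain now stands apart from a second hydroxy chain, with a 2.7-fold lower number from compound 2 to compound 4 (0.43 log units; beyond the scatter) and thus beyond the scatter, though modest, so the separation no longer rests on a 2.8-fold higher number from compound 1 to compound 2 (0.44 log units; beyond the scatter) alone. Nothing available accounts for these differences.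

The compounds shown leave open whether the gap belongs to the piperidin-1-yl ring or to any chain ending in an amine, which a dimethylamino or a simple primary amine at the same chain end would test. They also leave open how far this position tolerates other chain ends, such as a carboxylic acid, or a hydroxy chain much longer than those of compound 1 and compound 4.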